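Bromo to methyl on a shared core: cytotoxicity outlook

This account rests on a few compounds, and the source may have more. Where it says the series, first, only, none or still open, it means among the compounds named here.

Measured compounds:
compound 1 `Clc1cccc([C@@H]2C[C@@H]3Cc4ccc5ccccc5c4N2O3)c1`: > 300000 nM
compound 2 `Brc1cccc([C@@H]2C[C@@H]3Cc4ccc5ccccc5c4N2O3)c1`: > 250000 nM

In an ADME assay on THP-1 cells (Homo sapiens) for cytotoxicity, read by MTT assay, with a stated time of 72 h (on this read-out higher numbers stand for lower toxicity in this test and lower numbers for higher toxicity in this test), compound 1 gives > 300000 nM, which is a limit of the assay and not a number. Compound 2 likewise gives only a limit in this assay, namely > 250000 nM. For the measured compounds named here, the one measured step, a step that the two limits leave unreadable from compound 1 to compound 2, is therefore unreadable: both ends rest on limits, the limit of > 250000 nM in this assay, at which 1 of the 2 values shown sits, and (the limit of > 300000 nM in this assay, at which 1 of the 2 values shown sits), so its size cannot be told.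

Compound 3 `Cc1cccc([C@@H]2C[C@@H]3Cc4ccc5ccccc5c4N2O3)c1` differs from compound 2 by methyl in place of bromo on an aromatic carbon. Going by the values given here, the only step that bears on this change is the unreadable one from compound 1 to compound 2, so no size of step can be drawn from it. With compound 2 standing at a limit, the expectation for compound 3 is likewise a limit rather than a number, with no step beyond the scatter. The estimated step is a step that the limit leaves unreadable from compound 2 to compound 3. Compound 3 is accordingly expected to give about 300000 nM, in the range 100000 nM to 1000000 nM.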

Compound 3, half-maximal cytotoxic concentration: > 300000 nM
Compound 3 gave a limit, no number; the forecaster's own chance of this, stated with the estimate: 85%; the middle value sits exactly at the limit.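

In this assay compound 1, compound 2 and compound 3 all give limits of the assay rather than numbers, and the steps between them cannot be read. The compounds shown leave open at what concentration any of the three would turn toxic, and whether swapping chloro, bromo and methyl changes that concentration.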